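The source may hold more compounds than are shown below. What is called first, only, known or untested is meant among the compounds shown, and "the series" means these compounds.

- compound 1 `CC[C@@H]1NC(=O)[C@H](CCCNC(=N)N)NC(=O)[C@](C)(NC(=O)C(C)C)CCCCN(C)C(=O)[C@@H](c2ccc(Cl)cc2)NC1=O`: > 1 h
- compound 2 `CC[C@@H]1NC(=O)[C@H](CCCNC(=N)N)NC(=O)[C@](C)(NC(=O)C(C)C)CCCCN(C)C(=O)[C@@H](c2ccccc2)NC1=O`: > 1 h
- compound 3 `CC[C@@H]1NC(=O)[C@H](CCCNC(=N)N)NC(=O)[C@](C)(NC(=O)C(C)C)CCCCNC(=O)[C@@H](c2ccccc2)NC1=O`: > 1 h

In an ADME assay on microsomes (Mus musculus) for metabolic stability (a higher number here means that the compound lasts longer, a lower number that the compound disappears faster), compound 2 gives > 1 h, which is a limit and not a number. The other two values are limits as well (the limit of > 1 h in this assay, at which 3 of the 3 values shown sit).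

Compound 4 `CC[C@@H]1NC(=O)[C@H](CCCNC(=N)N)NC(=O)[C@](C)(NC(=O)C(C)C)CCCCN(C)C(=O)[C@@H](c2ccc(F)cc2)NC1=O` keeps the core of compound 2 and carries one change: fluoro in place of hydrogen on an aromatic carbon. The closest measured change, also on an aromatic carbon, is a step that the two limits leave unreadable from compound 1 to compound 2. The change at an amide-type nitrogen in a ring, a step that the two limits leave unreadable from compound 2 to compound 3, lies elsewhere and bears on it less. Neither step has a readable size, so no step beyond the scatter is expected. The estimated step that the limit leaves unreadable from compound 2 to compound 4 reflects that expectation. For compound 4 the expected half-life is 2 h, with an estimated range of 1 h to 6 h.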

Compound 4, half-life: > 1 h
Compound 4 gave a limit, no number; the forecaster's own chance of this, stated with the estimate: 90%; the middle value does not contradict the limit.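

No step can be read from compound 2 or compound 1 to compound 4 in this assay, because the values are limits and not numbers: the limit of > 1 h in this assay, at which 4 of the 4 values shown sit.

On these data alone, the actual half-lives stay open, and so does whether hydrogen, fluoro or chloro on the aromatic carbon makes any difference.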